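A few compounds are considered here, and "the series" means these few. Any claim that something is new, unique, unknown or untested is made for them only; others in the source may bear on it.

The measured compounds, with their values in a physicochemical assay for lipophilicity, measured as octanol-water partition; a higher number here means a more lipophilic compound, a lower number a more polar compound:

compound 1, `CC1=C(C(=O)OCc2ccccn2)C(c2ccc([N+](=O)[O-])cc2)C2=C(CCCC2=O)N1`: 1.88
compound 2, `CC1=C(C(=O)OCc2cccnc2)C(c2ccc([N+](=O)[O-])cc2)C2=C(CCCC2=O)N1`: 1.51
compound 3, `CC1=C(C(=O)OCc2cccnc2)C(c2ccc(Cl)cc2)C2=C(CCCC2=O)N1`: 1.87

Compound 4, `CC1=C(C(=O)OCc2ccccn2)C(c2ccc(Cl)cc2)C2=C(CCCC2=O)N1`, has not yet been measured in this assay. It differs from compound 3 in one place: pyridin-2-yl in place of pyridin-3-yl on a saturated chain carbon bound to an oxygen next to a carbonyl group. The same change separates compound 2 from compound 1, (pyridin-2-yl in place of pyridin-3-yl on a saturated chain carbon bound to an oxygen next to a carbonyl group), and there it gave a number 0.37 log units higher from compound 2 to compound 1 (beyond the scatter). The two cores are themselves related by a single change, (chloro in place of nitro on an aromatic carbon), which gave a number 0.36 log units higher from compound 2 to compound 3 (beyond the scatter), so compound 3 and compound 1 lie close together in this assay. The place of the change is described in the same words in both pairs, so the change from compound 3 to compound 4 is the same change as that from compound 2 to compound 1, not merely the same kind. Among the compounds with values here, only one measured pair shows this change, so the expectation rests on a single step. For compound 4 the expected step is a number 0.37 log units higher from compound 3 to compound 4 (beyond the scatter), because compound 1 stands against compound 2 with a number 0.37 log units higher from compound 2 to compound 1 (beyond the scatter). Compound 4 is therefore estimated at 2.24 in this assay, with a range from 1.95 to 2.55.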

Compound 4, partition coefficient: 2.24
Estimate against measurement, compound 4: no gap at the digits printed, and the stated range covers the measured number.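

In this assay the change from pyridin-3-yl to pyridin-2-yl gave a number 0.37 log units higher from compound 3 to compound 4 (beyond the scatter) on the chloro core and a number 0.37 log units higher from compound 2 to compound 1 (beyond the scatter) on the nitro core, so the step carried over from one core to the other at the same size. The four compounds close consistently: chloro in place of nitro gave a number 0.36 log units higher from compound 1 to compound 4 (beyond the scatter) with pyridin-2-yl and a number 0.36 log units higher from compound 2 to compound 3 (beyond the scatter) with pyridin-3-yl, which means that in this set the two changes simply add. This is one closed set of two cores, so it does not show that the step would hold on any other core, and nothing available explains why it held here.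

The compounds shown leave open whether the same step would appear with an amine or a carboxylic acid on the aromatic carbon that carries chloro or nitro here. They also leave open how this assay would respond if a phenyl group or a longer chain stood in place of the pyridinylmethyl group.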